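This account rests on a few compounds, and the source may have more. Where it says the series, first, only, none or still open, it means among the compounds named here.

Measured so far:
Compound 1 `CC(C)[C@@H](NC(=O)OC(C)(C)C)C(=O)Nc1ccc2ncnc(Nc3cccc(Br)c3)c2c1`: > 50000 nM
Compound 2 `C[C@@H](NC(=O)OC(C)(C)C)C(=O)Nc1ccc2ncnc(Nc3ccc(F)c(Cl)c3)c2c1`: > 50000 nM

Both entries come from a functional assay on HepG2 cells (Homo sapiens) for antiproliferative activity, read by sulforhodamine B assay, with a stated time of 72 h (on this read-out higher numbers stand for weaker inhibition and lower numbers for stronger inhibition), a test of how strongly a compound holds back the growth of these cells. Neither entry is an exact number. Compound 2 stands at > 50000 nM, which is a limit of the assay. Compound 1 gives > 50000 nM, which is also a limit. Among the measured compounds shown here, no measured compound in this set therefore has an exact value to compare with compound 2.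

Compound 3 `CC(C)[C@@H](NC(=O)OC(C)(C)C)C(=O)Nc1ccc2ncnc(Nc3ccc(F)c(Cl)c3)c2c1` differs from compound 2 in one place: isopropyl in place of methyl on a saturated chain carbon bound to an amide-type nitrogen and a carbonyl carbon. This puts isopropyl in place of methyl on a saturated chain carbon bound to an amide-type nitrogen and a carbonyl carbon.

For the measured compounds named here, with no measured step to draw on, the expected change in this assay is none beyond the scatter, in either direction, and that expectation rests on (the limit of > 50000 nM in this assay, at which 2 of the 2 values shown sit). The step expected is a number no higher from compound 2 to compound 3 (the limit leaves the size open). For compound 3 the estimated value is 50000 nM, with an expected range from 20000 nM to 100000 nM.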

Compound 3, half-maximal inhibitory concentration: > 50000 nM
Compound 3: a limit, no number; the forecaster's own chance of this, stated with the estimate: 75%; the middle value sits exactly at the limit.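

In this assay compound 3 gives > 50000 nM, which is a limit and not a number. No step from compound 1 or compound 2 to compound 3 can be read, because all three compounds sit at a limit: the limit of > 50000 nM in this assay, at which 3 of the 3 values shown sit.

The compounds shown leave open whether isopropyl in place of methyl, or 3-chloro-4-fluorophenyl in place of 3-bromophenyl, changes growth inhibition at all.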